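Trimethoxystyryl indoles: effect of methyl on indole nitrogen

A few compounds are considered here, and "the series" means these few. Any claim that something is new, unique, unknown or untested is made for them only; others in the source may bear on it.

Measured compounds:
- compound 1, `COc1cc(/C=C\c2c[nH]c3ccccc23)cc(OC)c1OC`, 3230 nM
- compound 2, `COc1cc(/C=C\c2cn(C)c3ccccc23)cc(OC)c1OC`, 3090 nM
- compound 3, `COc1cc(/C=C/c2ccc3[nH]ccc3c2)cc(OC)c1OC`, 250 nM

Values are from a functional assay on HeLa cells (Homo sapiens) for inhibition; on this read-out higher numbers stand for weaker inhibition and lower numbers for stronger inhibition. The change methyl in place of hydrogen on an aromatic nitrogen gives a 1.0-fold lower number from compound 1 to compound 2 (0.02 log units; within the scatter). Compound 3 stands lowest; its difference from the core of compound 1 is not broken down here. Compound 4, `COc1cc(/C=C/c2ccc3c(ccn3C)c2)cc(OC)c1OC`, is not yet measured; it differs from compound 3 by methyl in place of hydrogen on an aromatic nitrogen. This is the same kind of change as that from compound 1 to compound 2, not the same: in that pair the place lies two ring bonds from the ring atom that bears a large group, which is not stated for compound 4. On the evidence of a 1.0-fold lower number from compound 1 to compound 2 (0.02 log units; within the scatter), the step of a 1.2-fold higher number from compound 3 to compound 4 (0.08 log units; within the scatter) is expected to stay within scatter. Compound 4 is estimated at 300 nM, between 120 nM and 900 nM.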

Compound 4, half-maximal inhibitory concentration: 24 nM
Estimate against measurement, compound 4: 13-fold (1.10 log units) above; the measured number lies below the stated range.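

In this assay, methyl in place of hydrogen on an aromatic nitrogen gives a 10-fold lower number from compound 3 to compound 4 (1.02 log units; beyond the scatter), so the step seen on one core does not carry over to the other: the same change on two cores in this assay, a 1.0-fold lower number (0.02 log units; within the scatter) from compound 1 to compound 2 and a 10-fold lower number (1.02 log units; beyond the scatter) from compound 3 to compound 4, 10-fold (1.00 log units) apart, beyond the scatter of two such steps

For these two pairs, the size of the step depends on the core, and one pair gives no safe estimate for the other. The two cores differ in more than one place, so these pairs do not show which difference matters, or how the change behaves on any further core.

Still open, on these data alone, is how this assay responds on the core of compound 3 when the same nitrogen carries a longer chain or a chain ending in an amine. As far as these compounds go, a carboxylic acid at that place is also open.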